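Anilino to cyclopropylamino: the next step in the series

A few compounds are considered here, and "the series" means these few. Any claim that something is new, unique, unknown or untested is made for them only; others in the source may bear on it.

In a functional assay on MOLT-4 cells (Homo sapiens) for antiproliferative activity, read by MTT assay, with a stated time of 48 h (on this read-out lower numbers stand for stronger inhibition and higher numbers for weaker inhibition), compound 1 `COc1ccc(Nc2nc(Nc3cnn(CCCCCCC(=O)NO)c3)ncc2Cl)cc1` gives 170 nM and compound 2 `O=C(CCCCCCn1cc(Nc2ncc(Cl)c(Nc3ccccc3)n2)cn1)NO` gives 160 nM. These two numbers lie within the scatter of each other, so compound 2 stands level with compound 1 and no ranking follows.

Compound 3 `O=C(CCCCCCn1cc(Nc2ncc(Cl)c(NC3CC3)n2)cn1)NO` is the next compound to be read. The change is cyclopropyl in place of phenyl on a nitrogen on an aromatic ring, or anilino to cyclopropylamino.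

Among the measured compounds shown here, only one measured step bears on this, a 1.1-fold lower number from compound 1 to compound 2 (0.03 log units; within the scatter), with hydrogen in place of methoxy on an aromatic carbon. It stays within the scatter, but it leaves the aromatic ring in place. The data hold no case of that ring being replaced, so this step is only a weak guide.

A modest move towards a higher number is expected in this assay, starting from compound 2 at 160 nM. The estimated change is a 1.4-fold higher number from compound 2 to compound 3 (0.16 log units; within the scatter). For compound 3 the expected value is 230 nM, with an estimated range of 80 nM to 650 nM.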

Compound 3, half-maximal inhibitory concentration: 150 nM
Compound 3: the middle estimate sits 1.5-fold (0.19 log units) above what was measured, and the stated range covers the measured number.
By their numbers in this assay, from the lowest: compounds 3, 2 and 1 (each within the scatter of the next).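

In this assay, the aromatic ring on this nitrogen gives way to cyclopropyl, with 3 heavy atoms entering for the 6 of phenyl and the read-out level: a 1.1-fold lower number from compound 2 to compound 3 (0.03 log units; within the scatter). The comparison with the substituted ring gives the same picture, a 1.1-fold lower number from compound 1 to compound 3 (0.05 log units; within the scatter), so the three compounds shown cannot be ranked, and this position accepts a three-membered non-aromatic ring as well as either six-membered aromatic ring, whereas the earlier pair spoke only to a methoxy group on a ring that stayed in place. No available evidence accounts for this level reading.

On these data alone, what a larger or more open group on the same nitrogen would give remains open, for example cyclohexyl, benzyl or a plain methyl, and so does the effect of a group carrying a basic amine or a carboxylic acid there. As far as these compounds go, with all three values in a single cell line, it is also open whether the same level reading would hold in any other assay.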